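Pyrazoline amides and sulfonamides: an unmeasured analogue

The source may hold more compounds than are shown below. What is called first, only, known or untested is meant among the compounds shown, and "the series" means these compounds.

Compound 1 `CN1CCN(c2ccc(C3=NN(C(=O)c4ccc(C(F)(F)F)cc4)C(c4ccc(N(C)C)cc4)C3)cc2)CC1` gives 93.2% in a functional assay on NCI-H1975 cells (Homo sapiens) for inhibition, read by sulforhodamine B assay, tested at 10 uM; on this read-out lower numbers stand for less inhibition and higher numbers for more inhibition at the one concentration tested (going by the name of the read-out). Compound 2 `CN1CCN(c2ccc(C3=NN(S(C)(=O)=O)C(c4ccc(N(C)C)cc4)C3)cc2)CC1` gives -1.3% in this assay; the change methylsulfonyl in place of (4-(trifluoromethyl)phenyl)carbonyl on an amine nitrogen in a ring produced a number 94.5 percentage points lower from compound 1 to compound 2 (beyond the scatter). Compound 3 `CN(C)c1ccc(C2CC(c3ccc(-n4ccnc4)cc3)=NN2C(=O)c2ccc(C(F)(F)F)cc2)cc1` gives 15.9% in this assay; its core differs from compound 1 by 1H-imidazol-1-yl in place of 4-methylpiperazin-1-yl on an aromatic carbon, with a number 77.3 percentage points lower from compound 1 to compound 3 (beyond the scatter).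

Compound 4 `CN(C)c1ccc(C2CC(c3ccc(-n4ccnc4)cc3)=NN2S(C)(=O)=O)cc1` has not yet been measured in this assay. It differs from compound 3 by methylsulfonyl in place of (4-(trifluoromethyl)phenyl)carbonyl on an amine nitrogen in a ring. This is the same kind of change as that from compound 1 to compound 2, though the surroundings differ: in compound 1 the ring atom two ring bonds away bears a large group, in compound 3 it bears a 4-(1H-imidazol-1-yl)phenyl group.

A step of a number 15.9 percentage points lower from compound 3 to compound 4 (beyond the scatter) is expected from compound 3 to compound 4 in this assay, far smaller than the earlier one because compound 3 starts low at 15.9% and the read-out cannot fall much further. Compound 4 is estimated at 0%, between -15% and 15%.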

Compound 4, a percentage reported as inhibition, at one concentration (the size of the read-out at that concentration, not a potency): -3.8%
For compound 4 the middle estimate is 3.8 percentage points above the measured one, and the stated range covers the measured number.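

In this assay, the swap to methylsulfonyl on the amine nitrogen in a ring lowers the number on both cores, but not by the same amount, giving a number 19.7 percentage points lower from compound 3 to compound 4 (beyond the scatter): the same change on two cores in this assay, a number 94.5 percentage points lower (beyond the scatter) from compound 1 to compound 2 and a number 19.7 percentage points lower (beyond the scatter) from compound 3 to compound 4, 74.8 percentage points apart, beyond the scatter of two such steps. The swap to 1H-imidazol-1-yl does not carry over either, giving a number 2.5 percentage points lower from compound 2 to compound 4 (within the scatter): the same change on two cores in this assay, a number 77.3 percentage points lower (beyond the scatter) from compound 1 to compound 3 and a number 2.5 percentage points lower (within the scatter) from compound 2 to compound 4, 74.8 percentage points apart, beyond the scatter of two such steps. Compound 2 and compound 4 both sit at the bottom of the read-out, and these four compounds cannot separate a true dependence on the core from a floor in the read-out, nor do they give potency, as only one concentration is tested.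

Open, on these data alone, is whether a 4-(trifluoromethyl)benzenesulfonyl group on that nitrogen behaves like the amide or like methylsulfonyl. Also open, as far as these compounds go, is whether a morpholine in place of 4-methylpiperazin-1-yl keeps the level of compound 1.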